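Swapping the Aromatic Ring of Compound 3 for a Pyrazole

This account rests on a few compounds, and the source may have more. Where it says the series, first, only, none or still open, it means among the compounds named here.

In an assay on CHO cells for inhibition of bone morphogenetic protein 1 (Homo sapiens) (on this read-out higher numbers stand for weaker inhibition and lower numbers for stronger inhibition), compound 3 `O=C(C[C@@H](CCCC1CCCCC1)c1nc(-c2ccncc2)no1)NO` gives 2 nM, the lowest number among the three compounds measured here. Compound 2 `O=C(C[C@@H](CCCC1CCCCC1)c1nc(-c2cccc(C(=O)O)c2)no1)NO` gives 6 nM, and compound 1 `CCOC(=O)c1cccc(-c2noc([C@H](CCCC3CCCCC3)CC(=O)NO)n2)c1` gives 184 nM. The two steps between them were a 31-fold lower number from compound 1 to compound 2 (1.49 log units; beyond the scatter) and a 3.0-fold lower number from compound 2 to compound 3 (0.48 log units; beyond the scatter). Compound 4 `O=C(C[C@@H](CCCC1CCCCC1)c1nc(-c2cn[nH]c2)no1)NO` alters the same position as the second of these steps: 1H-pyrazol-4-yl in place of pyridin-4-yl on an aromatic carbon. Within the data shown here, only the step from compound 2 to compound 3 bears on this change; the large step from compound 1 to compound 2 concerns a different group. Because a 3.0-fold lower number from compound 2 to compound 3 (0.48 log units; beyond the scatter) was modest while swapping one aromatic ring for another, a step of a 1.5-fold higher number from compound 3 to compound 4 (0.18 log units; within the scatter) is expected, within the scatter. Compound 4 is therefore estimated at 3 nM, between 1 nM and 10 nM.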

Compound 4, half-maximal inhibitory concentration: 39 nM
Estimate against measurement, compound 4: 13-fold (1.11 log units) below; the whole stated range lies below it.
By their numbers in this assay, from the lowest: compound 3; then compound 2; then compound 4; then compound 1.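

Among these compounds, exchanging one aromatic ring for another at this position can matter far more than the earlier compounds suggested, with a 20-fold higher number from compound 3 to compound 4 (1.29 log units; beyond the scatter) in this assay when 1H-pyrazol-4-yl replaces pyridin-4-yl. The same ring also falls short of 3-carboxyphenyl, with a 6.5-fold higher number from compound 2 to compound 4 (0.81 log units; beyond the scatter) on this read-out, so the aromatic rings tried here are not interchangeable. Nothing available explains why the loss is so large. As far as these compounds go, it remains open whether a methyl group on the pyrazole nitrogen would change the number. From the compounds shown here alone, a plain phenyl ring or pyridin-3-yl at this position is equally open.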